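Swapping 4-fluoro-3-nitrophenyl for 4-(trifluoromethyl)phenyl

The source may hold more compounds than are shown below. What is called first, only, known or untested is meant among the compounds shown, and "the series" means these compounds.

Values so far in a functional assay on MV4-11 cells (Homo sapiens) for antiproliferative activity, read by luminescence and CellTiter-Glo, with a stated time of 72 h (a higher number here means a weaker inhibitor, a lower number a stronger inhibitor), for the series
- compound 1 `CNc1cc(-c2ccc3cnn(Cc4ccc(C)cc4)c3c2)cn(C)c1=O` gives 3280 nM as its read-out
- compound 2 `CNc1cc(-c2ccc3cnn(Cc4ccc(F)c([N+](=O)[O-])c4)c3c2)cn(C)c1=O` gives 130 nM as its read-out

Compound 2 holds the lower of the two numbers and is the stronger inhibitor of the pair. Within the data shown here, the only measured step is a 25-fold lower number from compound 1 to compound 2 (1.40 log units; beyond the scatter) and it came with 4-fluoro-3-nitrophenyl in place of 4-methylphenyl. Compound 3 `CNc1cc(-c2ccc3cnn(Cc4ccc(C(F)(F)F)cc4)c3c2)cn(C)c1=O` has 4-(trifluoromethyl)phenyl in place of 4-fluoro-3-nitrophenyl on a saturated chain carbon bound to an aromatic nitrogen and so gives up the group that compound 2 alone carries. Among the measured compounds shown here, the measured step, read in reverse, is the sole guide, and no measurement covers the entering group. A sizeable rise in the number is expected, probably short of the full size of that step, so the estimated change is a 10-fold higher number from compound 2 to compound 3 (1.00 log units; beyond the scatter) in the weaker direction. In this assay compound 3 is estimated at 1300 nM with 350 nM to 4500 nM as the expected range.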

Compound 3, half-maximal inhibitory concentration: 4370 nM
For compound 3 the middle estimate is 3.4-fold (0.53 log units) below the measured one, within the range that was stated.
By their numbers in this assay, from the lowest: compound 2; then compounds 1 and 3 (each within the scatter of the next).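

In this assay, 4-(trifluoromethyl)phenyl in place of 4-fluoro-3-nitrophenyl on a saturated chain carbon bound to an aromatic nitrogen gives a 34-fold higher number from compound 2 to compound 3 (1.53 log units; beyond the scatter), so the low number of compound 2 does not survive this change. Trifluoromethyl in place of methyl on an aromatic carbon gives a 1.3-fold higher number from compound 1 to compound 3 (0.12 log units; within the scatter), which lies within the scatter, so this pair does not separate those two groups, and of the three compounds only compound 2 stands apart. No evidence is at hand that accounts for either step.

The compounds shown leave open whether the nitro group, the fluorine or the two together go with the low number of compound 2. Also open, on these data alone, is how a phenyl ring carrying a nitrile or an amine would read in this position.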